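This account rests on a few compounds, and the source may have more. Where it says the series, first, only, none or still open, it means among the compounds named here.

In a functional assay on MCF7 cells (Homo sapiens) for antiproliferative activity, read by MTT assay, with a stated time of 24 h (on this read-out lower numbers stand for stronger inhibition and higher numbers for weaker inhibition), compound 3 (`COC(=O)c1scc(-c2ccc(NC(=O)c3cccc(C(F)(F)F)c3)cc2)c1OC`) gives 26200 nM and sits within the scatter of compound 2 (`COC(=O)c1scc(-c2ccc(NC(=O)c3ccccn3)cc2)c1OC`) at 19200 nM while compound 1 (`COC(=O)c1scc(-c2ccc(NC(=O)c3ccc4ccccc4c3)cc2)c1OC`) at 90 nM lies far lower. Compound 4 (`COC(=O)c1scc(-c2ccc(NC(=O)c3ccc(F)c(Cl)n3)cc2)c1OC`) differs from compound 3 as follows (6-chloro-5-fluoropyridin-2-yl in place of 3-(trifluoromethyl)phenyl on a carbonyl carbon). The closest evidence is a 1.4-fold higher number from compound 2 to compound 3 (0.14 log units; within the scatter) for a swap between pyridin-2-yl and 3-(trifluoromethyl)phenyl, which stayed within the scatter. The large steps of a 210-fold higher number from compound 1 to compound 2 (2.33 log units; beyond the scatter) and a 290-fold higher number from compound 1 to compound 3 (2.46 log units; beyond the scatter) both remove naphthalen-2-yl, which neither compound 3 nor compound 4 carries. No step beyond the scatter is therefore expected in this assay for this change, and a 1.6-fold lower number from compound 3 to compound 4 (0.21 log units; within the scatter) is the estimated step. Compound 4 is expected at 16000 nM (estimated range 4000 nM to 50000 nM).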

Compound 4, half-maximal inhibitory concentration: 10300 nM
Estimate against measurement, compound 4: 1.6-fold (0.19 log units) above, and the stated range covers the measured number.
By their numbers in this assay, from the lowest: compound 1; then compounds 4, 2 and 3 (each within the scatter of the next, the first and the last beyond it).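

In this assay, for the compounds shown here, 6-chloro-5-fluoropyridin-2-yl on the carbonyl carbon gives the only step beyond the scatter among the groups lacking naphthalen-2-yl (a 2.5-fold lower number from compound 3 to compound 4 (0.41 log units; beyond the scatter)), and that step is modest. Against pyridin-2-yl, the same group stays within the scatter (a 1.9-fold lower number from compound 2 to compound 4 (0.27 log units; within the scatter)), and the gap to naphthalen-2-yl remains large (a 110-fold higher number from compound 1 to compound 4 (2.06 log units; beyond the scatter)). Nothing measured here accounts for these differences. The compounds shown leave open how quinolin-2-yl on the same carbonyl carbon would compare with naphthalen-2-yl, and whether chlorine or fluorine alone on pyridin-2-yl gives any step.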